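A few compounds are considered here, and "the series" means these few. Any claim that something is new, unique, unknown or untested is made for them only; others in the source may bear on it.

Compound 1 `CC(C)Cc1ccc2c(NCCCNCc3ccco3)ccnc2c1` and compound 2 `COc1cccc(CNCCCNc2ccnc3cc(-c4ccc(C(C)(C)C)cc4)ccc23)c1O` share a core. In a physicochemical assay for acid dissociation, compound 1 gives 9.47, and compound 2 gives 9.47; the two values are within the scatter of each other, so compound 1 stands level with compound 2. Compound 3 `Fc1ccc(Cc2ccc3c(NCCCNCc4ccco4)ccnc3c2)c(Cl)c1` differs from compound 1 by 2-chloro-4-fluorophenyl in place of isopropyl on a saturated chain carbon bound to an aromatic carbon. For the measured compounds named here, no measured pair shows a change of this kind, and the one comparison at hand shows no shift, so no step beyond the scatter is expected. Compound 3 is expected to give 9.4, between 9 and 9.8. The expected step from compound 1 to compound 3 is a number 0.07 log units lower from compound 1 to compound 3 (within the scatter).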

Compound 3, acid dissociation constant: 9.47
For compound 3 the middle estimate is 0.07 log units below the measured one; the range from low to high includes it.
By their numbers in this assay, from the lowest: compounds 1, 2 and 3 (each within the scatter of the next).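

For the compounds shown here, the swap of 2-chloro-4-fluorophenyl for isopropyl, on a saturated chain carbon bound to an aromatic carbon, is the first one-place comparison in this assay, and it gives no change at the digits printed from compound 1 to compound 3 (within the scatter). So at this position, a larger group carrying an aromatic ring of carbon only, with chlorine and fluorine on it, leaves the reading level with that of the smaller isopropyl. No supporting measurement bears on why the reading holds here.

On these data alone, whether a group of another kind at this place, such as an amine or a carboxylic acid, would also leave the reading level stays open. The same holds for a longer chain.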